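The compounds below may be only part of what the source reports. "The series", "measured", "known", "first", "only" and "open" are said of these compounds alone.

Measured in a functional assay on MIA PaCa-2 cells (Homo sapiens) for inhibition, read by MTT assay, with a stated time of 48 h, tested at 10 uM; on this read-out lower numbers stand for less inhibition of growth and higher numbers for more inhibition of growth at the one concentration tested:
- Compound 1 `Cc1cc(=O)c2c(O)c(CN3CCCC3CO)c(O)c([C@H]3CCN(C)C[C@H]3O)c2o1`: 13%
- Compound 2 `CCOC(=O)N1CCN(Cc2c(O)c([C@H]3CCN(C)C[C@H]3O)c3oc(C)cc(=O)c3c2O)CC1`: 4%

Compound 2, at 4%, stands within the scatter of compound 1, so the two values cannot be ranked. The next compound, compound 3 `Cc1cc(=O)c2c(O)c(CN3CCCC3C(=O)O)c(O)c([C@H]3CCN(C)C[C@H]3O)c2o1`, carries 2-carboxypyrrolidin-1-yl in place of 4-(ethoxycarbonyl)piperazin-1-yl on a saturated chain carbon bound to an aromatic carbon. Among the measured compounds shown here, only one measured step bears on this change, at the same place: a number 9 percentage points lower from compound 1 to compound 2 (within the scatter). That step exchanged 2-(hydroxymethyl)pyrrolidin-1-yl for the group that now leaves. For the measured compounds named here, no measured compound carries 2-carboxypyrrolidin-1-yl, so the data give no direct reading of it. Going by the values given here, with only that small step as a guide, no shift beyond the scatter is expected in this assay. The expected change is a number 4 percentage points higher from compound 2 to compound 3 (within the scatter). For compound 3 the estimate is 8%, with an expected range from 0% to 20%.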

Compound 3, percent growth inhibition at one concentration: 10%
Compound 3: the middle estimate sits 2 percentage points below what was measured; the measured number falls inside the stated range.
By their numbers in this assay, from the lowest: compounds 2, 3 and 1 (each within the scatter of the next).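

Among the compounds shown here, compound 3 gives the first reading of 2-carboxypyrrolidin-1-yl on a saturated chain carbon bound to an aromatic carbon: in this assay the exchange for 4-(ethoxycarbonyl)piperazin-1-yl gives a number 6 percentage points higher from compound 2 to compound 3 (within the scatter) and so does not separate the two groups. It also adds a narrower comparison, since carboxy in place of hydroxymethyl on a saturated ring carbon gives a number 3 percentage points lower from compound 1 to compound 3 (within the scatter) and leaves these two compounds unranked as well. No measurement at hand bears on why these groups give readings within the scatter of one another.

On these data alone, whether an open-chain amine such as diethylamino, or a longer chain ending in a carboxylic acid, at this place would move the number beyond the scatter remains open. So does whether any change on the shared core would do so.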